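The source may hold more compounds than are shown below. What is called first, only, known or untested is meant among the compounds shown, and "the series" means these compounds.

Compound 1 `CC1(C)CC(=O)C=C(Nc2ccc(Br)cc2)C1` gives in a functional assay on PBMC cells (Homo sapiens) for inhibition, read by thymidine incorporation, with a stated time of 72 h (a higher number here means a weaker inhibitor, a lower number a stronger inhibitor), only a limit, > 50 ug/mL. Compound 2 `CCCCSC(=S)C1=C(Nc2ccc(Br)cc2)CC(C)(C)CC1=O` likewise gives in this assay only a limit, > 50 ug/mL. Compound 3 `CCCCCCCCCCCSC(=S)C1=C(Nc2ccc(Br)cc2)CC(C)(C)CC1=O` also gives in this assay only a limit, > 50 ug/mL.

Compound 3 therefore stands nowhere that a number can fix: its result is a limit, and the two further results shown are limits as well, all sitting at the limit of > 50 ug/mL in this assay, at which 3 of the 3 values shown sit. The step that the two limits leave unreadable from compound 1 to compound 2 and the step that the two limits leave unreadable from compound 2 to compound 3 are both left unreadable by the two limits on either side of them.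

Compound 4 `CC1(C)CC(=O)C(C(=S)SCCO)=C(Nc2ccc(Br)cc2)C1` differs from compound 3 by hydroxy in place of nonyl on a saturated chain carbon, two bonds along the chain from a sulfur. Within the data shown here, the only measured step that touches this chain is the step from compound 2 to compound 3, where heptyl in place of hydrogen on the saturated chain carbon gave an unreadable step; the step from compound 1 to compound 2 concerns the group of seven heavy atoms itself and is unreadable too. Among the measured compounds shown here, no measured step can thus set a size or a direction for the change to hydroxy, and the step from compound 3 to compound 4 is expected to be a step that the limit leaves unreadable from compound 3 to compound 4, most likely ending at the same limit. Compound 4 is estimated in this assay at 60 ug/mL, in the range 15 ug/mL to 250 ug/mL.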

Compound 4, half-maximal inhibitory concentration: 8.3 ug/mL
Compound 4: middle estimate off by 7.2-fold (0.86 log units), on the high side; the whole stated range lies above it.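

In this assay this chain proves able to change the result: hydroxy in place of nonyl on a saturated chain carbon, two bonds along the chain from a sulfur, gives an at least 6.0-fold lower number from compound 3 to compound 4 (0.77 log units; beyond the scatter), and hydroxy in place of ethyl at that carbon gives an at least 6.0-fold lower number from compound 2 to compound 4 (0.77 log units; beyond the scatter). Adding the whole group to the core also becomes readable once the chain ends in hydroxy, with an at least 6.0-fold lower number from compound 1 to compound 4 (0.77 log units; beyond the scatter), whereas the steps among compound 1, compound 2 and compound 3 cannot be read. The hydroxy-bearing chain thus sets compound 4 apart from the other three, although each of these steps gives only a minimum size, as the other three compounds stop at a limit: the limit of > 50 ug/mL in this assay, at which 3 of the 4 values shown sit.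

The compounds shown leave open whether the hydroxy itself is needed, or whether an amine, a carboxylic acid or a methoxy group on the same chain carbon would serve as well. They also leave open how a longer chain ending in hydroxy would compare with compound 4, and whether changing the bromine on the aniline ring to chlorine would alter the result.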